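Side-chain capping and oral exposure in the rat series

This account rests on a few compounds, and the source may have more. Where it says the series, first, only, none or still open, it means among the compounds named here.

Compound 1 `CN(C)CC(=O)NCc1c(CN(C)[C@H]2CCCc3cccnc32)ncc2ccccc12`: 10%
Compound 2 `CN(C)C(=O)NCCCc1c(CN(C)[C@H]2CCCc3cccnc32)ncc2ccccc12`: 20%

Among the measured compounds shown here, in an in vivo ADME assay on the whole organism for pharmacokinetics, with Rattus norvegicus as the target, at a dose of 3 mg/kg by the oral route (on this read-out higher numbers stand for higher oral bioavailability and lower numbers for lower oral bioavailability), compound 2 gives 20%, which lies within the scatter of compound 1, the only other measured compound; the two cannot be told apart on these numbers.

The next compound to consider is compound 3 `CN(Cc1ncc2ccccc2c1CCCNS(C)(=O)=O)[C@H]1CCCc2cccnc21`, which carries methylsulfonyl in place of dimethylcarbamoyl on an amine nitrogen. The difference counts as follows: methylsulfonyl in place of dimethylcarbamoyl on an amine nitrogen. The same change, cut one bond further out, reads (dimethylcarbamoyl)amino to methanesulfonamido.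

For the measured compounds named here, one measured step bears on this, and it is only indirect: a number 10 percentage points higher from compound 1 to compound 2 (within the scatter). Going by the values given here, no measured compound carries methylsulfonyl, so the evidence for this exchange is thin and the range has to stay wide. Among the compounds with values here, with that single step inside the scatter as the only guide, no step beyond the scatter is expected in this assay, and the estimated move is no change at the digits printed from compound 2 to compound 3 (within the scatter). The estimate for compound 3 is 20%, with an expected range of 8% to 40%.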

Compound 3, oral bioavailability: 4%
For compound 3 the middle estimate is 16 percentage points above the measured one; measured number below the stated range.
By their numbers in this assay, from the lowest: compounds 3, 1 and 2 (each within the scatter of the next, the first and the last beyond it).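

Among the compounds shown here, with the chain held constant, the cap on the amine nitrogen does matter in this assay: methylsulfonyl in place of dimethylcarbamoyl gives a number 16 percentage points lower from compound 2 to compound 3 (beyond the scatter), the only step so far that lies beyond the scatter. The picture is narrower against the other side chain, where the exchange of (((dimethylamino)methyl)carbonyl)amino for 2-(methanesulfonamido)ethyl gives a number 6 percentage points lower from compound 1 to compound 3 (within the scatter), so the methanesulfonamido compound separates from the dimethylcarbamoyl compound only and not from both of its comparators. Nothing measured on these compounds accounts for the difference between the two caps.

Still open, going by these compounds, is whether the lower reading belongs to methylsulfonyl in particular or would also follow from other replacements of dimethylcarbamoyl on this nitrogen, such as an acetyl group, or from the free primary amine on the same chain. A single pair on a single chain also leaves open whether the gap between the two caps would hold on a longer chain, or with a carboxylic acid at the end of the side chain in place of either cap.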